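Trifluoromethyl Gives Way to Methyl on the Aromatic Ring

The compounds below may be only part of what the source reports. "The series", "measured", "known", "first", "only" and "open" are said of these compounds alone.

In a functional assay on K562 cells (Homo sapiens) for antiproliferative activity, read by MTT assay (on this read-out lower numbers stand for stronger inhibition and higher numbers for weaker inhibition), compound 1 `C/C(=N\NC(=S)NCCCCCC(=O)NO)c1ccc(Br)cc1` gives 960 nM while compound 2 `COc1cccc(/C(C)=N/NC(=S)NCCCCCC(=O)NO)c1` gives 1910 nM and compound 3 `C/C(=N\NC(=S)NCCCCCC(=O)NO)c1cccc(C(F)(F)F)c1` stands at 1400 nM among them. All three numbers lie within the usual scatter of one another, so they support no ranking.

Compound 4 `C/C(=N\NC(=S)NCCCCCC(=O)NO)c1cccc(C)c1` has not yet been measured. It shares the core of compound 3 and carries methyl in place of trifluoromethyl on an aromatic carbon. For the measured compounds named here, two measured steps bear on this change, and both altered a group on the ring. The closer guide is a 1.4-fold lower number from compound 2 to compound 3 (0.13 log units; within the scatter) (trifluoromethyl in place of methoxy on an aromatic carbon). The other is a 2.0-fold higher number from compound 1 to compound 2 (0.30 log units; within the scatter) (3-methoxyphenyl in place of 4-bromophenyl). Going by the values given here, neither step goes beyond the scatter, although only three compounds stand behind that observation and none of them carries methyl on the ring.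

The change is therefore expected to do little, and the data favour no direction. The estimated step in this assay is a 1.1-fold higher number from compound 3 to compound 4 (0.03 log units; within the scatter) and would stay within the scatter. Compound 4 is expected near 1500 nM with an estimated range from 700 nM to 3000 nM for its measurement.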

Compound 4, half-maximal inhibitory concentration: 3840 nM
The estimate for compound 4 lay 2.6-fold (0.41 log units) below the measured number; the whole stated range lies below it.
By their numbers in this assay, from the lowest: compounds 1, 3, 2 and 4 (each within the scatter of the next, the first and the last beyond it).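

In this assay, for the compounds shown here, the exchange of trifluoromethyl for methyl on this aromatic carbon gives a 2.7-fold higher number from compound 3 to compound 4 (0.44 log units; beyond the scatter) and so goes beyond the scatter, which no earlier step did; the group on this carbon can therefore move the number measurably, even though the first three compounds gave no sign of it. Methyl in place of methoxy on the same carbon gives a 2.0-fold higher number from compound 2 to compound 4 (0.30 log units; within the scatter) and stays within the scatter, while 3-methylphenyl in place of 4-bromophenyl gives a 4.0-fold higher number from compound 1 to compound 4 (0.60 log units; beyond the scatter) and goes beyond it, so only some of the pairs involving compound 4 separate clearly. Nothing available explains why trifluoromethyl and methyl part in this way.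

The compounds shown leave open what an amine or a carboxylic acid on this same aromatic carbon would do to the number, and whether a longer chain such as ethyl or propyl would follow methyl or fall closer to trifluoromethyl. They also leave open whether methyl on another carbon of the ring would give a similar result, as all of this rests on only four compounds in a single assay.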